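The source may hold more compounds than are shown below. What is called first, only, known or untested is meant among the compounds shown, and "the series" means these compounds.

Compound 1 `O=C(CSc1nc(Nc2ccccc2)c2ccccc2n1)Nc1ccc(F)cc1` gives 16500 nM in a functional assay on NCI-H1975 cells (Homo sapiens) for inhibition, read by MTT assay, with a stated time of 72 h; a higher number here means a weaker inhibitor, a lower number a stronger inhibitor. Compound 2 `O=C(CSc1nc(Nc2ccccc2)c2ccccc2n1)Nc1ccc(Cl)cc1` gives 8040 nM in this assay. Compound 3 `C=CC(=O)Nc1cccc(NC(=O)CSc2nc(Nc3ccc(Cl)c(Cl)c3)c3ccccc3n2)c1` gives 19100 nM in this assay, the highest of the three numbers.

Compound 2 and compound 1 differ in one place, (fluoro in place of chloro on an aromatic carbon), and that exchange gave a 2.1-fold higher number from compound 2 to compound 1 (0.31 log units; beyond the scatter). How the core of compound 3 differs from that of compound 2 is not broken down here.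

Compound 4 `C=CC(=O)Nc1cccc(NC(=O)CSc2nc(Nc3ccc(F)c(Cl)c3)c3ccccc3n2)c1` differs from compound 3 by fluoro in place of chloro on an aromatic carbon. The surroundings are not identical: in compound 4 the exchanged position is ortho to a chloro group, so this is the same kind of change as from compound 2 to compound 1, not the same change.

Compound 4 is expected to show a step of similar size, a 1.7-fold higher number from compound 3 to compound 4 (0.22 log units; within the scatter), resting on the measured 2.1-fold higher number from compound 2 to compound 1 (0.31 log units; beyond the scatter). Compound 4 is therefore estimated at 32000 nM in this assay, likely between 13000 nM and 75000 nM.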

Compound 4, half-maximal inhibitory concentration: > 50000 nM
Compound 4 ended at the assay's limit; the forecaster's own chance of this, stated with the estimate: 20%; middle value at least 1.5-fold (0.19 log units) from the limit.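

The exchange of fluoro for chloro on an aromatic carbon gave a higher number on both cores in this assay, and on the second core it gave an at least 2.6-fold higher number from compound 3 to compound 4 (0.41 log units; beyond the scatter). The direction of the step thus carried across these two pairs, but they do not show whether its size carried as well: the same change on two cores in this assay, a 2.1-fold higher number (0.31 log units; beyond the scatter) from compound 2 to compound 1 and an at least 2.6-fold higher number (0.41 log units; beyond the scatter) from compound 3 to compound 4; the limit leaves it open whether they differ. Compound 4 gives > 50000 nM, which is a limit of the assay and not a number: the limit of > 50000 nM in this assay, at which 1 of the 4 values shown sits.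

With only two pairs, the compounds shown do not establish how general this direction is across the series. As far as these compounds go, how a bromo or a methoxy group in the same place would compare on either core remains open.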